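The source may hold more compounds than are shown below. What is called first, only, known or untested is meant among the compounds shown, and "the series" means these compounds.

Compound 1, `CCOC(=O)C(=O)Nc1cccccc1=O`, stands highest of the three compounds measured in a functional assay on the whole organism (strain Sprague-Dawley CD) for inhibition, with Rattus norvegicus as the target, read by paw edema, at a dose of 100 mg/kg by the oral route (a lower number here means a weaker effect, a higher number a stronger effect of the compound at the dose given), where compound 1 gives 91%. Compound 2, `CCOC(=O)C(=O)Nc1ccccc(Oc2ccccc2)c1=O`, gives 9%, and compound 3, `CCOC(=O)C(=O)Nc1c(C)ccccc1=O`, gives 37%. Compound 4, `CCOC(=O)C(=O)Nc1ccc(OC)ccc1=O`, differs from compound 1 by methoxy in place of hydrogen on an aromatic carbon. Among the compounds with values here, two measured steps bear on this change, each adding a group to the same ring of compound 1: a number 82 percentage points lower from compound 1 to compound 2 (beyond the scatter) and a number 54 percentage points lower from compound 1 to compound 3 (beyond the scatter). Both are large falls, so a fall beyond the scatter is also expected for the methoxy group, though its size is uncertain since neither earlier group matches it. Compound 4 is therefore estimated at 45%, between 15% and 80%. The expected step is a number 46 percentage points lower from compound 1 to compound 4 (beyond the scatter).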

Compound 4, a percentage reported as inhibition, in the whole organism at one dose (the size of the read-out at that dose, not a potency): 53%
Compound 4: middle estimate off by 8 percentage points, on the low side; the measured number falls inside the stated range.
By their numbers in this assay, from the lowest: compound 2; then compound 3; then compound 4; then compound 1.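

In this assay, methoxy on an aromatic carbon three ring bonds from the ring atom that bears a group of 8 heavy atoms also lowers the effect, with a number 38 percentage points lower from compound 1 to compound 4 (beyond the scatter) at this dose. Compound 1, with hydrogen at that carbon, therefore remains highest of the four, and each of the three groups shown on its ring goes with a fall beyond the scatter. The data available give no reason for this fall. Still open, as far as these compounds go, is whether an amine or a carboxylic acid at this carbon would keep the effect of compound 1.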